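The compounds below may be only part of what the source reports. "The series", "measured", "known", "first", "only" and "open" are said of these compounds alone.

In a functional assay on PC-3 cells (Homo sapiens) for cytotoxicity, read by WST assay, with a stated time of 72 h (on this read-out higher numbers stand for weaker inhibition and lower numbers for stronger inhibition), compound 3 `CCOc1ccc(C2(c3ccc(O)cc3)C(=O)Nc3c2ccc(F)c3F)cc1` gives 24 nM, the higher of two single numbers, while compound 1 `O=C1Nc2c(ccc(F)c2F)C1(c1ccccc1)c1ccc(O)cc1` gives 8.9 nM. Compound 2 `COc1ccc(C2(c3ccc(O)cc3)C(=O)Nc3c2ccc(F)c3F)cc1` has no single number, with entries of 2 nM; 2.2 nM; > 1000 nM (3 entries). The last entry of compound 2 is a limit of the assay. Compound 4 `O=C1Nc2c(ccc(F)c2F)C1(c1ccc(O)cc1)c1ccc(F)c(F)c1` differs from compound 3 as follows: 3,4-difluorophenyl in place of 4-ethoxyphenyl on a saturated ring carbon. Thus 3,4-difluorophenyl stands in place of 4-ethoxyphenyl on a saturated ring carbon. Among the measured compounds shown here, one measured step bears on this change, made on the same ring: a 2.7-fold higher number from compound 1 to compound 3 (0.43 log units; beyond the scatter). With the ethoxy gone, a partial reversal of that modest step is expected, so the expected step is a 2.4-fold lower number from compound 3 to compound 4 (0.38 log units; beyond the scatter). For compound 4 the estimated value is 10 nM, with an expected range of 2.5 nM to 40 nM.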

Compound 4, half-maximal inhibitory concentration: 19 nM
Compound 4: the middle estimate sits 1.9-fold (0.28 log units) below what was measured; measured number inside the range.
By their numbers in this assay, from the lowest: compound 1; then compounds 4 and 3 (each within the scatter of the next).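

In this assay, the exchange on the saturated ring carbon gives a 1.3-fold lower number from compound 3 to compound 4 (0.10 log units; within the scatter), so 3,4-difluorophenyl and 4-ethoxyphenyl cannot be told apart here. Set against the plain phenyl, the new ring gives a 2.1-fold higher number from compound 1 to compound 4 (0.33 log units; beyond the scatter), so the rise seen with ethoxy is not confined to that group. Compound 2 cannot be placed in this pattern, since it has no single number and its last entry is a limit of the assay: the several entries of compound 2 in this assay, 2 nM; 2.2 nM; > 1000 nM (3 entries)

On these data alone, what remains open is how an amine or a carboxylic acid on this phenyl ring would compare with compound 1.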